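Shortening the Isothiocyanate Arm: Compound 2 to Compound 3

A few compounds are considered here, and "the series" means these few. Any claim that something is new, unique, unknown or untested is made for them only; others in the source may bear on it.

Measured so far:
compound 1, `CN(C)C(=O)c1cc2cnc(Nc3ccc(C(=O)NCCCCCCN=C=S)cc3)nc2n1C1CCCC1`: 49.4%
compound 2, `CN(C)C(=O)c1cc2cnc(Nc3ccc(NC(=O)CCCCCN=C=S)cc3)nc2n1C1CCCC1`: 34.3%

Of the compounds shown here, two have been measured in a functional assay on NCI-H1299 cells (Homo sapiens) for inhibition, read by CCK-8 assay, with a stated time of 72 h, tested at 1 uM; on this read-out lower numbers stand for a weaker effect and higher numbers for a stronger effect at the one concentration tested. Compound 2 stands lowest of the two: a number 15.1 percentage points lower from compound 1 to compound 2 (beyond the scatter), a modest drop that lies beyond the scatter. Compound 3, `CN(C)C(=O)c1cc2cnc(Nc3ccc(N=C=S)cc3)nc2n1C1CCCC1`, differs from compound 2 in one place: a group of 3 heavy atoms (1 carbon, 1 nitrogen, 1 sulfur; no ring) in place of a group of 11 heavy atoms (7 carbon, 2 nitrogen, 1 oxygen, 1 sulfur; no ring), on an aromatic carbon. The isothiocyanate therefore sits directly on the aromatic ring rather than at the end of an amide-linked chain.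

Among the compounds with values here, only one measured step exists, from compound 1 to compound 2, and it concerns a different change, so it bears on the present step only loosely; it shows that altering this arm can move the read-out by a modest amount. The step is estimated as a number 6.3 percentage points lower from compound 2 to compound 3 (within the scatter), a small decrease that may not exceed the scatter. Compound 3 is expected to give 28%, with a range from 8% to 48%.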

Compound 3, a percentage reported as inhibition, at one concentration (the size of the read-out at that concentration, not a potency): 46.9%
For compound 3 the middle estimate is 18.9 percentage points below the measured one; the measured number falls inside the stated range.
By their numbers in this assay, from the lowest: compound 2; then compounds 3 and 1 (each within the scatter of the next).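

In this assay, placing the isothiocyanate directly on the aromatic carbon, para to a large group, gives a number 12.6 percentage points higher from compound 2 to compound 3 (beyond the scatter), so the amide-linked chain is not needed at this position to reach the upper level of the read-out seen so far. Measured against the longer arm, the change gives a number 2.5 percentage points lower from compound 1 to compound 3 (within the scatter), which leaves the two compounds level and shows that the read-out here does not simply follow the size of the group. Nothing available explains why the short group and the longer arm read alike, or why compound 2 stands apart from both. The compounds shown leave open whether the isothiocyanate itself matters, which an amine on the same aromatic carbon would test. They also leave open how an amide-linked chain shorter than those in compound 1 and compound 2 would read.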